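Swapping the sulfonamide on the piperidine for a pyridinylaminomethyl

This account rests on a few compounds, and the source may have more. Where it says the series, first, only, none or still open, it means among the compounds named here.

Measured compounds:
Compound 1 `c1ccc(CNCC2CCN(CCCc3c[nH]c4ccc(-n5cnnc5)cc34)CC2)cc1`: 28 nM
Compound 2 `CN(C1CCN(CCCc2c[nH]c3ccc(-n4cnnc4)cc23)CC1)S(=O)(=O)c1ccccc1`: 10 nM
Compound 3 `CN(Cc1ccc(S(C)(=O)=O)cc1)C1CCN(CCCc2c[nH]c3ccc(-n4cnnc4)cc23)CC1`: 140 nM

In an assay on CHO cells for displacement of a labelled ligand from 5-hydroxytryptamine receptor 1B (Homo sapiens) (a higher number here means a weaker inhibitor, a lower number a stronger inhibitor), compound 2 gives the lowest of the three numbers; the nearest is compound 1 at a 2.8-fold lower number from compound 1 to compound 2 (0.45 log units; beyond the scatter) in reverse, and the furthest is compound 3 at a 14-fold higher number from compound 2 to compound 3 (1.15 log units; beyond the scatter). Compound 4 `c1ccc(NCC2CCN(CCCc3c[nH]c4ccc(-n5cnnc5)cc34)CC2)nc1` differs from compound 2 by ((pyridin-2-yl)amino)methyl in place of methyl(phenylsulfonyl)amino on a saturated ring carbon. Going by the values given here, two measured steps bear on this change. The step from compound 1 to compound 2, a 2.8-fold lower number from compound 1 to compound 2 (0.45 log units; beyond the scatter), shows that moving away from an arylmethyl-amino group toward methyl(phenylsulfonyl)amino lowered the number modestly; compound 4 returns to a group closer in kind to the (benzylamino)methyl of compound 1. The step of a 14-fold higher number from compound 2 to compound 3 (1.15 log units; beyond the scatter) shows that exchanging the phenylsulfonyl for a benzyl-type group raised the number strongly. A moderate rise is therefore expected in this assay, roughly back toward compound 1. For compound 4 the estimate is 40 nM, within a range from 15 nM to 150 nM. This expectation corresponds to a step of a 4.0-fold higher number from compound 2 to compound 4 (0.60 log units; beyond the scatter).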

Compound 4, half-maximal inhibitory concentration: 3.3 nM
Beside the measured number, compound 4's estimate is 12-fold (1.08 log units) above it; measured number below the stated range.
By their numbers in this assay, from the lowest: compound 4; then compound 2; then compound 1; then compound 3.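

In this assay, the methyl(phenylsulfonyl)amino group on this saturated ring carbon is not needed for a low number, since ((pyridin-2-yl)amino)methyl goes lower still (with a 3.0-fold lower number from compound 2 to compound 4 (0.48 log units; beyond the scatter)). Compound 1 had suggested that an amine-linked aryl group at this place costs binding, but the group on that amine nitrogen proves decisive, with pyridin-2-yl in place of benzyl giving the larger step (with an 8.5-fold lower number from compound 1 to compound 4 (0.93 log units; beyond the scatter)). No measurement at hand explains either step.

Pyridin-2-yl and benzyl differ in both the ring and the carbon that links it, so a phenyl group on the same amine nitrogen would be needed to tell which of the two matters. As far as these compounds go, it also remains open whether a methyl group on that amine nitrogen would keep the number this low.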